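Bromo-to-hydrogen step transferred across two cores

A few compounds are considered here, and "the series" means these few. Any claim that something is new, unique, unknown or untested is made for them only; others in the source may bear on it.

Compound 1 `COc1cc2c(cc1OC)C(c1ccc(Br)cc1)=NNC(=O)C2` and compound 3 `COc1cc2c(cc1OC)C(c1ccccc1)=NNC(=O)C2` share a core; in a functional assay on the whole organism with Mus musculus as the target (a lower number here means that less compound is needed, a higher number that more compound is needed for the effect), compound 1 gives 110 umol/kg and compound 3 gives 33.9 umol/kg. The difference between them is hydrogen in place of bromo on an aromatic carbon and the step is a 3.2-fold lower number from compound 1 to compound 3 (0.51 log units; beyond the scatter). Compound 2 `COc1cc2c(cc1OC)C(c1ccc(Br)cc1)=NN(C)C(=S)C2` gives 105 umol/kg in this assay, a value that lies within the scatter of that of compound 1. How the core of compound 2 differs from the core of compound 1 is not broken down here. Compound 4 `COc1cc2c(cc1OC)C(c1ccccc1)=NN(C)C(=S)C2` is not yet measured. It differs from compound 2 by hydrogen in place of bromo on an aromatic carbon, the same change as from compound 1 to compound 3, at the same place in both pairs. For the measured compounds named here, compound 4 is expected to show a step of a 3.1-fold lower number from compound 2 to compound 4 (0.49 log units; beyond the scatter), a size taken directly from the one measured instance, because a 3.2-fold lower number from compound 1 to compound 3 (0.51 log units; beyond the scatter) is the only guide to this change and the bromo compounds on the two cores give matching numbers. Compound 4 is therefore estimated at 34 umol/kg in this assay, with a likely range from 15 umol/kg to 80 umol/kg.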

Compound 4, dose for half-maximal effect: 30.6 umol/kg
Beside the measured number, compound 4's estimate is 1.1-fold (0.05 log units) above it; measured number inside the range.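

In this assay, the step from 4-bromophenyl to phenyl on the core of compound 2 is a 3.4-fold lower number from compound 2 to compound 4 (0.54 log units; beyond the scatter), and it matches the step seen on the core of compound 1: the same change on two cores in this assay, a 3.2-fold lower number (0.51 log units; beyond the scatter) from compound 1 to compound 3 and a 3.4-fold lower number (0.54 log units; beyond the scatter) from compound 2 to compound 4, 1.1-fold (0.02 log units) apart, within the scatter of two such steps. For these two cores, then, the size of the change carries over, and the measured step on one core served as a fair guide to the other. For the compounds shown here, this rests on only two pairs and one change in a single whole-organism read-out, so it does not show that the step would hold on any further core, nor does it explain why the two steps agree.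

As far as these compounds go, only bromo and hydrogen appear at this place on the phenyl ring, so it remains open whether a chloro, a nitrile or an amine there would fit the same pattern. The two cores also differ in both the carbonyl and the nitrogen methyl, and the compounds shown do not separate these two features.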